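Cytotoxicity notes on the aldehyde-to-bisulfite-adduct step

The compounds below may be only part of what the source reports. "The series", "measured", "known", "first", "only" and "open" are said of these compounds alone.

Measured so far:
compound 1 `CC(C)C[C@H](NC(=O)OCc1cccc(F)c1)C(=O)N[C@H](C=O)C[C@@H]1CCNC1=O` — > 200000 nM
compound 2 `COc1cccc2[nH]c(C(=O)N[C@@H](CC3CC3)C(=O)N[C@H](C=O)C[C@@H]3CCNC3=O)cc12` — > 200000 nM

In an ADME assay on Vero C1008 cells (Chlorocebus sabaeus) for cytotoxicity, read by luminescence and CellTiter-Glo, with a stated time of 24 h (a higher number here means that more compound is tolerated, a lower number that less compound is tolerated), compound 1 gives > 200000 nM, which is a limit of the assay and not a number. In this assay compound 2 likewise gives > 200000 nM, again a limit rather than a number. Going by the values given here, compound 2 therefore stands at the limit of > 200000 nM in this assay, at which 2 of the 2 values shown sit, and no measured step between these two compounds is available to judge the size of any effect.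

The next compound, compound 3 `COc1cccc2[nH]c(C(=O)N[C@@H](CC3CC3)C(=O)N[C@@H](C[C@@H]3CCNC3=O)C(O)S(=O)(=O)O)cc12`, is to be measured in this assay. It differs from compound 2 by hydroxy(sulfo)methyl in place of formyl on a saturated chain carbon bound to an amide-type nitrogen and a saturated chain carbon.

With both values at the limit, no step is expected beyond the scatter; the estimated step of a number no higher from compound 2 to compound 3 (the limit leaves the size open) is taken as essentially flat. Compound 3 is accordingly expected to sit at about 200000 nM, with a range of 100000 nM to 400000 nM, most likely reported again as a limit.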

Compound 3, half-maximal cytotoxic concentration: > 200000 nM
Compound 3: a limit, no number; the forecaster's own chance of this, stated with the estimate: 85%; the middle value lies on the limit itself.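

The step from compound 2 to compound 3 cannot be read in this assay, as both values are limits and not numbers: the limit of > 200000 nM in this assay, at which 3 of the 3 values shown sit.

The compounds shown leave open how much compound is tolerated beyond that limit, and whether hydroxy(sulfo)methyl and formyl differ in this respect at all.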